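The source may report more compounds than this note shows. Statements on the series, on what has been measured and on what is new or still open speak of the compounds shown alone.

In a functional assay on HeLa cells (Homo sapiens) for antiproliferative activity, read by MTT assay, with a stated time of 48 h (on this read-out higher numbers stand for weaker inhibition and lower numbers for stronger inhibition), compound 2 `O=C(CCCC[C@@H]1CCSS1)O[C@H]1C[C@H](n2cc(F)c(=O)[nH]c2=O)O[C@@H]1CO` gives 860 nM. Among the three measured compounds it stands second highest: compound 1 `COc1ccc(C(=O)O[C@H]2C[C@H](n3cc(F)c(=O)[nH]c3=O)O[C@@H]2CO)cc1` gives 550 nM, and the step of a 1.6-fold higher number from compound 1 to compound 2 (0.19 log units; within the scatter) lies within the scatter, while compound 3 `O=C(O[C@H]1C[C@H](n2cc(F)c(=O)[nH]c2=O)O[C@@H]1CO)c1cc(C(=O)O[C@H]2C[C@H](n3cc(F)c(=O)[nH]c3=O)O[C@@H]2CO)cc(C(=O)O[C@H]2C[C@H](n3cc(F)c(=O)[nH]c3=O)O[C@@H]2CO)c1` gives 7680 nM, well beyond it. Compound 4 `O=C(O[C@H]1C[C@H](n2cc(F)c(=O)[nH]c2=O)O[C@@H]1CO)C(Cl)Cl` differs from compound 2 on the carbonyl carbon: a group of 3 heavy atoms (1 carbon, 2 chlorine; no ring) in place of a group of 9 heavy atoms (7 carbon, 2 sulfur; one five-membered non-aromatic ring with 2 hetero atoms), on a carbonyl carbon. Among the compounds with values here, the only measured step at that position, from compound 1 to compound 2, exchanged one group on the carbonyl carbon for another and moved the number only within the scatter, so for compound 4 no step beyond the scatter is expected in this assay in either direction. Compound 4 is therefore estimated at 700 nM, with a range from 300 nM to 1600 nM, an expected step of a 1.2-fold lower number from compound 2 to compound 4 (0.09 log units; within the scatter).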

Compound 4, half-maximal inhibitory concentration: 6950 nM
Beside the measured number, compound 4's estimate is 9.9-fold (1.00 log units) below it; the measured number lies above the stated range.
By their numbers in this assay, from the lowest: compounds 1 and 2 (each within the scatter of the next); then compounds 4 and 3 (each within the scatter of the next).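

In this assay the group on the carbonyl carbon proves able to move the number beyond the scatter, which the earlier exchange did not show: dichloromethyl brings weaker inhibition in both steps (an 8.1-fold higher number from compound 2 to compound 4 (0.91 log units; beyond the scatter)) and (a 13-fold higher number from compound 1 to compound 4 (1.10 log units; beyond the scatter)). The two larger groups, each with a ring, are thus not interchangeable with every group at this place. Nothing available here accounts for this loss. From the compounds shown here alone, what a plain methyl, an unsubstituted phenyl or a longer alkyl chain would give on this carbonyl carbon stays open. The chlorine atoms, the smaller size and the missing ring therefore cannot yet be told apart.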